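The source may hold more compounds than are shown below. What is called first, only, known or untested is meant among the compounds shown, and "the series" means these compounds.

Compound 1 `CCN(CC)CCCNc1nc(-c2ccc(NC(=O)Nc3ccccc3)cc2)nc2c(Cl)c(Cl)sc12` and compound 2 `CCN(CC)CCCNc1nc(-c2ccc(NC(=O)Nc3ccccc3)cc2)nc2ccsc12` share a diethylaminopropylamino side chain and a phenylurea group; the difference between their two cores is not broken down here. In a functional assay on HT-29 cells (Homo sapiens) for cytotoxicity, read by MTT assay, with a stated time of 72 h (a higher number here means a weaker inhibitor, a lower number a stronger inhibitor), compound 1 gives 820 nM, and compound 2 gives 730 nM, the two lying within the usual scatter of each other. Compound 3 `CCN(CC)CCCNc1nc(-c2ccc(NC(=O)Nc3ccc(F)cc3)cc2)nc2c(Cl)c(Cl)sc12` carries fluoro in place of hydrogen on an aromatic carbon on the core of compound 1, and in this assay compound 3 gives 350 nM, which is a 2.3-fold lower number from compound 1 to compound 3 (0.37 log units; beyond the scatter). Compound 4 `CCN(CC)CCCNc1nc(-c2ccc(NC(=O)Nc3ccc(F)cc3)cc2)nc2ccsc12` is built from compound 2 by the same change, (fluoro in place of hydrogen on an aromatic carbon), placed on the core of compound 2. Among the compounds with values here, since the single measured instance of this change is a 2.3-fold lower number from compound 1 to compound 3 (0.37 log units; beyond the scatter), compound 4 is expected to show a step of about a 2.2-fold lower number from compound 2 to compound 4 (0.34 log units; beyond the scatter). Compound 4 is therefore estimated at 330 nM, with a likely range from 170 nM to 650 nM.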

Compound 4, half-maximal inhibitory concentration: 340 nM
The estimate for compound 4 lay 1.0-fold (0.01 log units) below the measured number, and the stated range covers the measured number.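

In this assay, within the data shown here, fluoro in place of hydrogen on the core of compound 2 gives a 2.1-fold lower number from compound 2 to compound 4 (0.33 log units; beyond the scatter), so the change carries over to a second core with much the same size as on the first: the same change on two cores in this assay, a 2.3-fold lower number (0.37 log units; beyond the scatter) from compound 1 to compound 3 and a 2.1-fold lower number (0.33 log units; beyond the scatter) from compound 2 to compound 4, 1.1-fold (0.04 log units) apart, within the scatter of two such steps This agreement rests on only two cores and one cell assay, so it does not show that the step would hold on any other core, and it does not say why the step arises.

The compounds shown leave open whether chloro, methoxy or methyl in that place would give a step of this size. They also leave open how a shorter or longer amine chain in place of the diethylaminopropylamino side chain would change the numbers.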